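Sulfanyl in place of propylamino on the shared core

This account rests on a few compounds, and the source may have more. Where it says the series, first, only, none or still open, it means among the compounds named here.

In a functional assay (spleen, spleen) for activation, with Mus musculus as the target (a lower number here means that less compound is needed, a higher number that more compound is needed for the effect), compound 2 `CCCNc1nc(N)c2nc(O)n(Cc3ccccc3)c2n1` gives 0.1 uM, the lowest of the two numbers shown. The nearest is compound 1 `Nc1ncnc2c1nc(O)n2Cc1ccc(F)cc1`, which gives 10 uM in this assay, a gap beyond the scatter. Compound 3 `Nc1ncnc2c1nc(I)n2Cc1ccccc1` gives > 10 uM in this assay, a limit of the assay and not a number, namely (the limit of > 10 uM in this assay, at which 1 of the 3 values shown sits). Compound 4 `Nc1nc(S)nc2c1nc(O)n2Cc1ccccc1` differs from compound 2 by sulfanyl in place of propylamino on an aromatic carbon. Among the compounds with values here, no single-change step between measured compounds is available, so the size of this change is untested. Compound 1 carries neither the propylamino nor the sulfanyl group and gives 10 uM, so some loss is expected for compound 4. Compound 4 is estimated at 1 uM (range 0.1 uM to 10 uM) in this assay, an expected step of a 10-fold higher number from compound 2 to compound 4 (1.00 log units; beyond the scatter).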

Compound 4, minimum effective concentration: 10 uM
For compound 4 the middle estimate is 10-fold (1.00 log units) below the measured one, within the range that was stated.
By their numbers in this assay, from the lowest: compound 2; then compounds 1 and 4 (each within the scatter of the next).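

In this assay, within the data shown here, the single change at this position gives a 100-fold higher number from compound 2 to compound 4 (2.00 log units; beyond the scatter) on the shared core, so the first direct comparison shows that the group on this aromatic carbon between two ring nitrogen atoms strongly affects the number. The step comes with a swap that leaves the counts of hydrogen-bond donors and acceptors unchanged. No measurement shown accounts for the size of this step. Open, as far as these compounds go, is whether a plain amine, an ethylamino chain or a butylamino chain at this carbon would keep the low number of compound 2 0.1 uM in this series.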